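Swapping Phenethyl for 3-Nitrophenyl on the Amide Carbonyl

A few compounds are considered here, and "the series" means these few. Any claim that something is new, unique, unknown or untested is made for them only; others in the source may bear on it.

Three amides built on a shared core have been measured in an assay on LtK cells with ATP-sensitive inward rectifier potassium channel 11 (Homo sapiens) as the target; on this read-out higher numbers stand for an effect only at larger amounts of compound and lower numbers for an effect already at smaller amounts. Compound 1 `CCCC(=O)Nc1c(C(O)(C(F)(F)F)C(F)(F)F)ccc2ccccc12` gives 131 nM. Compound 3 `O=C(CCc1ccccc1)Nc1c(C(O)(C(F)(F)F)C(F)(F)F)ccc2ccccc12` gives 1750 nM, the highest of the two numbers recorded, with compound 1 as its nearest neighbour. For compound 2 `CCCC(C)C(=O)Nc1c(C(O)(C(F)(F)F)C(F)(F)F)ccc2ccccc12` the assay reports only a limit, > 10000 nM.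

The step now followed leads from compound 3 to compound 4 `O=C(Nc1c(C(O)(C(F)(F)F)C(F)(F)F)ccc2ccccc12)c1cccc([N+](=O)[O-])c1`, whose change is 3-nitrophenyl in place of phenethyl on a carbonyl carbon.

For the measured compounds named here, two measured steps bear on this. Replacing methyl by phenyl on the chain gave a 13-fold higher number from compound 1 to compound 3 (1.13 log units; beyond the scatter), and a branched substituent on the carbonyl gave an at least 76-fold higher number from compound 1 to compound 2 (1.88 log units; beyond the scatter). Both enlargements of the amide substituent raised the number in this assay, and moving an aromatic ring directly onto the carbonyl is a change of comparable scale, so a number at or above that of compound 3 is expected, though its exact size is uncertain.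

Compound 4 is therefore estimated at 3000 nM, between 600 nM and 15000 nM, meaning an expected step of a 1.7-fold higher number from compound 3 to compound 4 (0.23 log units; within the scatter).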

Compound 4, half-maximal effective concentration: 117 nM
Estimate against measurement, compound 4: 26-fold (1.41 log units) above; the measured number lies below the stated range.
By their numbers in this assay, from the lowest: compounds 4 and 1 (each within the scatter of the next); then compound 3. At a limit, above all of these: compound 2.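

In this assay, an aromatic ring set directly on the carbonyl carbon did not carry the penalty seen with the larger groups before it: 3-nitrophenyl in place of phenethyl gave a 15-fold lower number from compound 3 to compound 4 (1.17 log units; beyond the scatter), so a large substituent at this position does not always raise the number. Compared with the propyl group, the same substituent gave a 1.1-fold lower number from compound 1 to compound 4 (0.05 log units; within the scatter), which makes compound 4 the one large group shown here that matches the short chain of compound 1. Against 1-methylbutyl the change gave an at least 85-fold lower number from compound 2 to compound 4 (1.93 log units; beyond the scatter), a step that rests on a limit of the assay: the limit of > 10000 nM in this assay, at which 1 of the 4 values shown sits.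

This change removes the two-carbon link and adds a nitro group in one move, so the effect of each alone stays unresolved. A plain phenyl on the carbonyl, or an amine or nitrile in place of the nitro group, would separate them.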